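Flavanone series: ethoxy replacement of the methoxymethoxy group

The source may hold more compounds than are shown below. What is called first, only, known or untested is meant among the compounds shown, and "the series" means these compounds.

Measured so far:
compound 1 `O=C1CC(c2ccccc2OCc2cccc(F)c2)Oc2ccccc21`: 15600 nM
compound 2 `COCOc1ccccc1C1CC(=O)c2ccccc2O1`: 32600 nM

In a functional assay on RAW264.7 cells (Mus musculus) for inhibition, read by Griess assay, with stated times of 1 h and 24 h (a lower number here means a stronger inhibitor, a higher number a weaker inhibitor), compound 1 gives 15600 nM, and compound 2 gives 32600 nM. Among the compounds with values here, compound 2 thus holds the higher of the two numbers; the one step recorded, a 2.1-fold higher number from compound 1 to compound 2 (0.32 log units; beyond the scatter), is modest but beyond the scatter.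

Compound 3 `CCOc1ccccc1C1CC(=O)c2ccccc2O1` differs from compound 2 as follows: methyl in place of methoxy on a saturated chain carbon bound to an oxygen on an aromatic ring. Within the data shown here, the only measured step concerns a different exchange, methoxy in place of 3-fluorophenyl on a saturated chain carbon bound to an oxygen on an aromatic ring, so it bears on the present change only loosely. With nothing else to go on, the expected step in this assay from compound 2 to compound 3 is a 1.1-fold lower number from compound 2 to compound 3 (0.04 log units; within the scatter), that is, none beyond the scatter. Compound 3 is estimated at 30000 nM, within a range of 12000 nM to 75000 nM.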

Compound 3, half-maximal inhibitory concentration: 38500 nM
Compound 3: middle estimate off by 1.3-fold (0.11 log units), on the low side; the measured number falls inside the stated range.
By their numbers in this assay, from the lowest: compound 1; then compounds 2 and 3 (each within the scatter of the next).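

In this assay, methyl in place of methoxy on a saturated chain carbon bound to an oxygen on an aromatic ring, which reads as methoxymethoxy to ethoxy, gives a 1.2-fold higher number from compound 2 to compound 3 (0.07 log units; within the scatter) and so does not separate the two compounds. Within the data shown here, the replacement of 3-fluorophenyl by methyl gives a 2.5-fold higher number from compound 1 to compound 3 (0.39 log units; beyond the scatter) and remains modest, so in this small set the only steps beyond the scatter are those leading away from compound 1, not the exchange between methoxy and methyl. No supporting measurement accounts for the size of either step.

As far as these compounds go, whether an amine or a carboxylic acid in place of the methyl would separate a new compound from compound 3 stays open. Also open, from the compounds shown here alone, is whether a longer chain would bring the number closer to that of compound 1.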